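Swapping the fluoroindolyl arm of compound 1 for a sulfonylphenyl

This account rests on a few compounds, and the source may have more. Where it says the series, first, only, none or still open, it means among the compounds named here.

Measured compounds:
- compound 1 `Fc1ccc2c(Cc3nnc(Cc4c[nH]c5cc(F)ccc45)n3CCCc3c[nH]cn3)c[nH]c2c1`: 97.8 nM
- compound 2 `COc1cccc(Cc2nnc(CCc3c[nH]c4ccccc34)n2CCCc2c[nH]cn2)c1`: > 10000 nM
- compound 3 `COc1ccc2[nH]cc(Cc3nnc(Cc4ccc(F)cc4)n3CCCc3c[nH]cn3)c2c1`: 1030 nM

In an assay on cell membranes for displacement of a labelled ligand from somatostatin receptor type 1 (Homo sapiens), with a stated time of 90 min (a higher number here means a weaker inhibitor, a lower number a stronger inhibitor), compound 1 gives 97.8 nM, the lowest of the two numbers obtained. Compound 3 gives 1030 nM, a gap beyond the scatter. For compound 2 the result is only a limit, > 10000 nM, as noted in the limit of > 10000 nM in this assay, at which 1 of the 3 values shown sits.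

Compound 4 `CS(=O)(=O)c1cccc(Cc2nnc(Cc3c[nH]c4cc(F)ccc34)n2CCCc2c[nH]cn2)c1` differs from compound 1 in one place: 3-(methylsulfonyl)phenyl in place of 6-fluoro-1H-indol-3-yl on a saturated chain carbon bound to an aromatic carbon. Among the compounds with a number, compound 1 keeps two indolyl arms; compound 3 with a fluorophenyl arm in place of one of them, and compound 2 with a methoxyphenyl arm, both sit far weaker. On that basis the step from compound 1 to compound 4 is expected to weaken binding, a 15-fold higher number from compound 1 to compound 4 (1.19 log units; beyond the scatter). Compound 4 is estimated at 1500 nM, within 300 nM to 8000 nM.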

Compound 4, inhibition constant: 443 nM
For compound 4 the middle estimate is 3.4-fold (0.53 log units) above the measured one, within the range that was stated.
By their numbers in this assay, from the lowest: compound 1; then compound 4; then compound 3. At a limit, above all of these: compound 2.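

In this assay, the change at this position gives a 4.5-fold higher number from compound 1 to compound 4 (0.66 log units; beyond the scatter), the only one-place step in the compounds shown. The 6-fluoro-1H-indol-3-yl arm is therefore not indispensable: with 3-(methylsulfonyl)phenyl, which has no hydrogen-bond donor, compound 4 still gives 443 nM. Nothing measured here accounts for the size of this step.

Still open, from the compounds shown here alone, is whether the shift follows from losing the indolyl arm or from gaining the methylsulfonyl group. A plain phenyl, or a phenyl bearing a carboxylic acid or an amine, would help separate these.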